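The source may hold more compounds than are shown below. What is called first, only, known or untested is meant among the compounds shown, and "the series" means these compounds.

Working notes on the series. Three members have been examined in a functional assay on MCF7 cells (Homo sapiens) for cytotoxicity, read by MTT assay, with a stated time of 48 h; a lower number here means a stronger inhibitor, a higher number a weaker inhibitor. Compound 1 `CC(C)(C)c1ccc(OC(=O)c2cn(-c3ccccc3)nc2-c2cccnc2)cc1` returns only a limit of the assay, > 100000 nM. Compound 2 `Cc1ccc(C(C)C)c(OC(=O)c2cn(-c3ccccc3)nc2-c2cccnc2)c1` gives 84200 nM. Among the compounds with values here, the one measured step between compounds differing in a single place is an at least 1.1-fold lower number from compound 1 to compound 2 (0.07 log units; that floor lies within the scatter), a change on the ester side, and its size sits within the scatter. Compound 3 `O=C(Oc1ccc2ccccc2c1)c1cn(-c2ccccc2)nc1-c1cccnc1` gives "nd(insoluble)" (no result reported), so it has no number at all and stands nowhere on the scale; of the values shown for the series, one is the limit of > 100000 nM in this assay, at which 1 of the 3 values shown sits.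

Compound 4 `O=C(Oc1ccc2ccccc2c1)c1cn(-c2ccccc2)nc1-c1ccncc1` differs from compound 3 by pyridin-4-yl in place of pyridin-3-yl on an aromatic carbon. Within the data shown here, no measured step touches this side of the shared core; the step from compound 1 to compound 2 alters the ester side instead, so nothing speaks to the size or direction of a change on the pyridyl group, and compound 3 offers no anchor to start from. What remains is the level of the series: compound 2 gives 84200 nM in this assay, the weak end of the scale. On that basis compound 4 is expected to lie near 95000 nM, estimated between 30000 nM and 300000 nM, with a fair chance that this assay again reports only a limit.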

Compound 4, half-maximal inhibitory concentration: 44500 nM
Estimate against measurement, compound 4: 2.1-fold (0.33 log units) above; the measured number falls inside the stated range.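

Within the data shown here, compound 3 has no number in this assay, so no step from compound 3 to compound 4 can be read, and compound 4 gives 44500 nM with no partner to set it against. The compounds shown leave open what pyridin-4-yl in place of pyridin-3-yl does to this read-out, and where compound 1 lies, its value being only a limit: the limit of > 100000 nM in this assay, at which 1 of the 4 values shown sits.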